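The source may hold more compounds than are shown below. What is called first, only, known or untested is meant among the compounds shown, and "the series" means these compounds.

Measured compounds:
compound 1, `OC[C@H]1O[C@@H](n2cnc3c(CSc4cccc(Br)c4)ncnc32)[C@H](O)[C@@H]1O`, 363 nM in an assay on isolated protein for binding affinity to Equilibrative nucleoside transporter 1 (Homo sapiens); on this read-out lower numbers stand for stronger inhibition and higher numbers for weaker inhibition
compound 2, `O=[N+]([O-])c1cccc(SCc2ncnc3c2ncn3[C@@H]2O[C@H](CO)[C@@H](O)[C@H]2O)c1`, 4.79 nM in this assay

Among the compounds with values here, compound 2 has the lower of the two numbers in this assay, and its only neighbour is compound 1, a step of a 76-fold lower number from compound 1 to compound 2 (1.88 log units; beyond the scatter). Compound 3, `N#Cc1ccc(SCc2ncnc3c2ncn3[C@@H]2O[C@H](CO)[C@@H](O)[C@H]2O)cc1`, is the unmeasured compound. It differs from compound 2 in one place: 4-cyanophenyl in place of 3-nitrophenyl on a sulfur. Within the data shown here, only one measured step exists, the one from compound 1 to compound 2, and it tells how a nitro group compares with a bromo group on the aromatic ring attached to the sulfur; it was large. Among the measured compounds shown here, no measured pair shows what a cyano group does, nor what moving the substituent to another place on that ring does, so the bearing of that step on compound 3 is indirect. Both a nitro and a cyano group are counted as hydrogen-bond acceptors, while bromo is not, so compound 3 is expected to stay closer to compound 2 than to compound 1, but with a weaker number than compound 2. The expected step is an 8.4-fold higher number from compound 2 to compound 3 (0.92 log units; beyond the scatter). The estimate for compound 3 in this assay is therefore 40 nM, with a range from 8 nM to 200 nM.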

Compound 3, half-maximal inhibitory concentration: 81.3 nM
Estimate against measurement, compound 3: 2.0-fold (0.31 log units) below; low and high end bracket the measured number.
By their numbers in this assay, from the lowest: compound 2; then compound 3; then compound 1.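

In this assay, putting 4-cyanophenyl in place of 3-nitrophenyl on the sulfur gives a 17-fold higher number from compound 2 to compound 3 (1.23 log units; beyond the scatter), so the very low number of compound 2 does not carry over to every replacement of that aryl group. Putting 4-cyanophenyl in place of 3-bromophenyl at the same sulfur gives a 4.5-fold lower number from compound 1 to compound 3 (0.65 log units; beyond the scatter), so the nitrile-bearing ring still improves on the bromo-bearing one, though by a smaller margin than the nitro-bearing ring does. The three compounds therefore show that this position responds strongly to what the aryl group carries, with compound 2 the strongest of the three, and nothing measured here explains why the numbers fall in this order.

Going by these compounds, the step between compound 2 and compound 3 changes both the group and its place on the ring, so the part played by each remains unknown. On these data alone, it also remains open how the number would respond to an amine or a carboxylic acid on that ring, or to a longer chain between the sulfur and the ring.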